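The source may hold more compounds than are shown below. What is called first, only, known or untested is meant among the compounds shown, and "the series" means these compounds.

Measured in a toxicity assay on NIH3T3 cells (Mus musculus) for cytotoxicity, read by resazurin assay; on this read-out higher numbers stand for an effect only at larger amounts of compound and lower numbers for an effect already at smaller amounts:
- compound 1 `N#Cc1ccc(NCc2cncn2Cc2ccc(-c3ccccc3)cc2)cc1-c1ccccc1`: > 1000 nM, a limit
- compound 2 `CC(C)OC(=O)c1ccc(NCc2cncn2Cc2ccc(-c3ccccc3)cc2)cc1-c1ccccc1`: > 10000 nM, a limit
- compound 3 `c1ccc(-c2ccc(Cn3cncc3CNc3ccc(N4CCCCC4)c(-c4ccccc4)c3)cc2)cc1`: > 1000 nM, a limit

Going by the values given here, no measured compound has an actual number, so compound 3 has no exact place. Compound 4 `c1ccc(-c2ccc(Cn3cncc3CNc3ccc(-c4noc5ccccc45)c(-c4ccccc4)c3)cc2)cc1` carries this change: a group of 9 heavy atoms (7 carbon, 1 nitrogen, 1 oxygen; one five-membered aromatic ring with 2 hetero atoms, one six-membered aromatic ring of carbon only) in place of a group of 6 heavy atoms (5 carbon, 1 nitrogen; one six-membered non-aromatic ring with 1 hetero atom), on an aromatic carbon. Three measured steps alter a group on that aromatic carbon: a step that the two limits leave unreadable from compound 1 to compound 2, a step that the two limits leave unreadable from compound 1 to compound 3 and a step that the two limits leave unreadable from compound 2 to compound 3. None gives a size or direction, so no definite shift beyond the scatter is expected in this assay. The expectation rests on compound 3 at its limit of > 1000 nM. The expected change is a step that the limit leaves unreadable from compound 3 to compound 4. For compound 4 the estimated value is 5000 nM, with an expected range of 1000 nM to 20000 nM.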

Compound 4, half-maximal effective concentration: > 10000 nM
Compound 4 gave a limit, no number; the forecaster's own chance of this, stated with the estimate: 75%; middle value at least 2.0-fold (0.30 log units) away from the limit.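

Going by these compounds alone, compound 4 gives > 10000 nM, a limit, so no step to it from compound 1, compound 2 or compound 3 can be read in this assay. The compounds shown leave open whether exchanging the group on this aromatic carbon shifts the read-out at all.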